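Isatin thiosemicarbazone series: cytotoxicity on MT4 cells

The compounds below may be only part of what the source reports. "The series", "measured", "known", "first", "only" and "open" are said of these compounds alone.

Measured compounds:
Compound 1, `CCN(CC)CN1C(=O)/C(=N\NC(=S)NO)c2cc(Cl)ccc21`: 562000 nM
Compound 2, `CONC(=S)N/N=C1\C(=O)N(CN(C)C)c2ccc(C)cc21`: 622000 nM
Compound 3, `CCN(CC)CN1C(=O)/C(=N\NC(=S)NOC)c2cc(C)ccc21`: 573000 nM

All three were run in an ADME assay on MT4 cells (Homo sapiens) for cytotoxicity, read by spectrophotometry, with a stated time of 5 days; a lower number here means that less compound is tolerated, a higher number that more compound is tolerated. In this assay compound 1 gives 562000 nM, compound 2 gives 622000 nM and compound 3 gives 573000 nM; the three numbers lie within the scatter of one another, so no order among them can be read.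

One pair differs in a single place: compound 3 and compound 2. The change is dimethylamino in place of diethylamino on a saturated chain carbon bound to an amide-type nitrogen in a ring and it made a step of a 1.1-fold higher number from compound 3 to compound 2 (0.04 log units; within the scatter), which is within the scatter.

Compound 4, `CN(C)CN1C(=O)/C(=N\NC(=S)NO)c2cc(Cl)ccc21`, has not been measured. It stands to compound 1 as compound 2 stands to compound 3: the change is dimethylamino in place of diethylamino on a saturated chain carbon bound to an amide-type nitrogen in a ring, at the same place in the same words, so it is the same change. The cores of compound 1 and compound 3 differ in more than one place, and that difference between the two cores is not broken down here.

Since the change occurs twice among these compounds and the measured instance is flat, the expected step for compound 4 is a 1.1-fold higher number from compound 1 to compound 4 (0.03 log units; within the scatter) in this assay, resting on compound 3 to compound 2 having shown a 1.1-fold higher number from compound 3 to compound 2 (0.04 log units; within the scatter) and on compound 1 at 562000 nM as the starting point. The estimate for compound 4 in this assay is 600000 nM, with a range expected from 350000 nM to 1000000 nM.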

Compound 4, half-maximal cytotoxic concentration: 610000 nM
The estimate for compound 4 lay 1.0-fold (0.01 log units) below the measured number; low and high end bracket the measured number.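

In this assay, dimethylamino in place of diethylamino on a saturated chain carbon bound to an amide-type nitrogen in a ring gives a 1.1-fold higher number from compound 1 to compound 4 (0.04 log units; within the scatter), and this step matches the one seen on the other core: the same change on two cores in this assay, a 1.1-fold higher number (0.04 log units; within the scatter) from compound 3 to compound 2 and a 1.1-fold higher number (0.04 log units; within the scatter) from compound 1 to compound 4, 1.0-fold (0.00 log units) apart, within the scatter of two such steps

The change therefore carries over as a flat step between these two cores, and the flat step on one core was a fair guide to the other. This does not show that the change is flat on every core or in any other read-out, since it rests on two pairs only, and the cores of compound 1 and compound 3 differ in more than one place, so no single part of that difference is tested.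

The amine on the chain carbon appears here only as dimethylamino or diethylamino, which leaves open whether a longer chain such as dipropylamino, or a carboxylic acid at the same place, would stay within the scatter as well. Also open, as far as these compounds go, is what the chloro and methyl groups and the hydroxy and methoxy ends of the cores each contribute when taken one at a time.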